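Five-membered heteroaryl swap on the shared core

The source may hold more compounds than are shown below. What is called first, only, known or untested is meant among the compounds shown, and "the series" means these compounds.

For the measured compounds named here, in a functional assay on NCI/ADR-RES cells (Homo sapiens) for inhibition, read by sulforhodamine B assay, with a stated time of 48 h (on this read-out higher numbers stand for weaker inhibition of growth and lower numbers for stronger inhibition of growth), compound 2 `CC1=CC[C@H](C(C)(C)NC(=S)N/N=C/c2ccco2)CC1` gives 9800 nM, the lowest of the two numbers known. Compound 1 `CC1=CC[C@H](C(C)(C)NC(=S)N/N=C/c2ccccc2Cl)CC1` gives 75000 nM; a 7.7-fold lower number from compound 1 to compound 2 (0.88 log units; beyond the scatter). Compound 3 `CC1=CC[C@H](C(C)(C)NC(=S)N/N=C/c2cccs2)CC1` differs from compound 2 by thiophen-2-yl in place of furan-2-yl on a carbon with a double bond to nitrogen. Going by the values given here, no measured step exchanges one five-membered aromatic ring for another; the only step known, from compound 1 to compound 2, replaces 2-chlorophenyl and does not bear directly on this change. For compound 3 the expected step is no change at the digits printed from compound 2 to compound 3 (within the scatter), none beyond the scatter. Compound 3 is therefore estimated at 9800 nM, with a range of 3000 nM to 32000 nM.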

Compound 3, concentration for 50% growth inhibition: 13600 nM
Beside the measured number, compound 3's estimate is 1.4-fold (0.14 log units) below it; low and high end bracket the measured number.
By their numbers in this assay, from the lowest: compounds 2 and 3 (each within the scatter of the next); then compound 1.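

In this assay, a 1.4-fold higher number from compound 2 to compound 3 (0.14 log units; within the scatter) means that thiophen-2-yl and furan-2-yl are not told apart on a carbon with a double bond to nitrogen. With a 5.5-fold lower number from compound 1 to compound 3 (0.74 log units; beyond the scatter) as well, the lower number relative to 2-chlorophenyl is seen with a second five-membered aromatic ring, not with furan-2-yl alone. Nothing available gives a reason for either step.

Open, on these data alone, is whether unsubstituted phenyl would sit with compound 1 or with these two rings. Also open, as far as these compounds go, is how pyridin-2-yl, or a thiophen-2-yl ring carrying an amine or a carboxylic acid, would read here.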